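Swapping thiophen-3-yl for 1H-indol-3-yl on a carbonyl carbon

This account rests on a few compounds, and the source may have more. Where it says the series, first, only, none or still open, it means among the compounds named here.

Compound 1 `COc1ccc(-c2cc3ccccc3nc2/C=C/C(=O)c2ccccn2)cc1`: 6140 nM
Compound 2 `COc1ccc(-c2cc3ccccc3nc2/C=C/C(=O)c2ccsc2)cc1`: 8210 nM

In a functional assay on A549 cells (Homo sapiens) for antiproliferative activity, read by XTT assay, with a stated time of 72 h (a lower number here means a stronger inhibitor, a higher number a weaker inhibitor), compound 2 gives 8210 nM, which lies within the scatter of compound 1 at 6140 nM, so the two cannot be told apart. Compound 3 `COc1ccc(-c2cc3ccccc3nc2/C=C/C(=O)c2c[nH]c3ccccc23)cc1` carries a new change on the carbonyl carbon: 1H-indol-3-yl in place of thiophen-3-yl on a carbonyl carbon. Among the compounds with values here, only one measured step bears on this, a 1.3-fold higher number from compound 1 to compound 2 (0.13 log units; within the scatter), where one ring group replaced another at that same carbon. That step did not bring in a group like 1H-indol-3-yl, so it offers only loose guidance. No step beyond the scatter is therefore expected in this assay, though the uncertainty is wide. The estimated change is a 1.6-fold lower number from compound 2 to compound 3 (0.22 log units; within the scatter) in this read-out. For compound 3 the expected value is 5000 nM, with an estimated range from 1200 nM to 15000 nM.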

Compound 3, half-maximal inhibitory concentration: > 10000 nM
Compound 3 gave a limit, no number; the forecaster's own chance of this, stated with the estimate: 10%; at least 2.0-fold (0.30 log units) between middle value and limit.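

In this assay compound 3 gives > 10000 nM, which is a limit of the assay and not a number. Only floors can be read from it, an at least 1.2-fold higher number from compound 2 to compound 3 (0.08 log units; that floor lies within the scatter) and an at least 1.6-fold higher number from compound 1 to compound 3 (0.21 log units; that floor lies within the scatter), so this change on the carbonyl carbon, which brings a second aromatic ring and a hydrogen-bond donor, cannot yet be told apart from the earlier ring swap. The true size of both steps stays unknown because the reading stops at the limit: the limit of > 10000 nM in this assay, at which 1 of the 3 values shown sits.

As far as these compounds go, whether the 1H-indol-3-yl group really weakens the effect on these cells therefore remains open. Also open, from the compounds shown here alone, is how this carbonyl carbon would respond to a plain phenyl ring, an open ethyl chain or a ring carrying a carboxylic acid.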